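Fluoro for methoxy on the aniline ring of the urea series

The source may hold more compounds than are shown below. What is called first, only, known or untested is meant among the compounds shown, and "the series" means these compounds.

Three ureas built on one shared core have been measured. Compound 1 `CCc1ccccc1NC(=O)N[C@H](C)c1ccccc1` gives 92% in an ADME assay on the whole organism with Oryza sativa as the target, tested at 10 uM; a higher number here means a weaker effect of the compound at the concentration tested, a lower number a stronger effect; compound 2 `CC(C)c1ccccc1NC(=O)N[C@H](C)c1ccccc1` gives 17%; compound 3 `COc1ccccc1NC(=O)N[C@H](C)c1ccccc1` gives 96%. Compound 3 stands with compound 1 within the usual scatter, a number 4 percentage points higher from compound 1 to compound 3 (within the scatter), while against compound 2 the gap is wide, a number 79 percentage points higher from compound 2 to compound 3 (beyond the scatter), and the lone step a number 75 percentage points lower from compound 1 to compound 2 (beyond the scatter) shows the same pattern on the saturated chain side.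

Compound 4 `C[C@@H](NC(=O)Nc1ccccc1F)c1ccccc1` is not yet measured. It differs from compound 3 by fluoro in place of methoxy on an aromatic carbon. The step that bears most on this is the swap of methoxy for ethyl on the same aromatic carbon, which moved the read-out only within the scatter; the large drops both came with isopropyl, not with any small group. A small group replacing another small group on that carbon is therefore expected to give no step beyond the scatter, a number 3 percentage points lower from compound 3 to compound 4 (within the scatter). Compound 4 is estimated at 93%, within 78% to 100%.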

Compound 4, a percentage reported as activity, at one concentration (the size of the read-out at that concentration, not a potency): 77%
For compound 4 the middle estimate is 16 percentage points above the measured one, outside the stated range (below it).
By their numbers in this assay, from the lowest: compound 2; then compound 4; then compounds 1 and 3 (each within the scatter of the next).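

In this assay this aromatic carbon responds to more than the isopropyl group: a number 19 percentage points lower from compound 3 to compound 4 (beyond the scatter) and a number 15 percentage points lower from compound 1 to compound 4 (beyond the scatter), so fluoro separates from methoxy and ethyl, which had stood within the scatter of each other. Fluoro still stays well apart from isopropyl, a number 60 percentage points higher from compound 2 to compound 4 (beyond the scatter), which places it between isopropyl and the ethyl and methoxy pair and shows that the read-out does not simply follow the heavy-atom count of the group here. No measured evidence accounts for the fluoro result.

On these data alone, whether chloro, tert-butyl or an amine on the same carbon would fall nearer fluoro or nearer isopropyl remains open. Also open, as far as these compounds go, is whether the step seen with fluoro would carry over to other carbons of the aromatic ring.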